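A tert-Butyl Group Added to the Benzyl Ring

The source may report more compounds than this note shows. Statements on the series, on what has been measured and on what is new or still open speak of the compounds shown alone.

Measured so far:
compound 1 `Nc1ccc(/C=C2\SC(=O)N(Cc3ccccc3)C2=O)cc1` 24000 nM
compound 2 `C=C(Br)C(=O)Nc1ccc(/C=C2\SC(=O)N(Cc3ccccc3)C2=O)cc1` 3000 nM

Of the compounds shown here, two have been measured in a functional assay on FM3A cells (Mus musculus) for cytotoxicity, read by cell counting, with a stated time of 2 days; on this read-out lower numbers stand for stronger inhibition and higher numbers for weaker inhibition. Compound 1 gives 24000 nM there, and compound 2 gives 3000 nM. Within the data shown here, the one measured step, an 8.0-fold lower number from compound 1 to compound 2 (0.90 log units; beyond the scatter), comes from placing (1-bromoethenyl)carbonyl on the nitrogen on the aromatic ring. On these two numbers compound 2 stands lowest; its nearest neighbour is compound 1, set apart by that same step.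

Compound 3 `C=C(Br)C(=O)Nc1ccc(/C=C2\SC(=O)N(Cc3ccc(C(C)(C)C)cc3)C2=O)cc1` differs from compound 2 by tert-butyl in place of hydrogen on an aromatic carbon. Among the measured compounds shown here, this change touches the benzyl ring rather than the nitrogen that was altered between compound 1 and compound 2, so the single step on record says nothing about its size or direction. For the measured compounds named here, with no comparable step available, the author expects the step of no change at the digits printed from compound 2 to compound 3 (within the scatter) to stay within the usual scatter. Compound 3 is therefore estimated at 3000 nM in this assay, with a range from 1000 nM to 9000 nM that reflects the absence of any guiding precedent.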

Compound 3, half-maximal inhibitory concentration: 4000 nM
Compound 3: middle estimate off by 1.3-fold (0.12 log units), on the low side; measured number inside the range.
By their numbers in this assay, from the lowest: compounds 2 and 3 (each within the scatter of the next); then compound 1.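

In this assay, tert-butyl on an aromatic carbon of the six-membered aromatic ring of carbon only, para to a large group, gives a 1.3-fold higher number from compound 2 to compound 3 (0.12 log units; within the scatter). Among these compounds, this is the first look at this position, and it shows that adding a group of 4 heavy atoms there leaves compound 2 and compound 3 indistinguishable on this read-out, unlike the change on the nitrogen, which gave an 8.0-fold lower number from compound 1 to compound 2 (0.90 log units; beyond the scatter). No measurement on these compounds offers an explanation for this result.

The compounds shown leave open whether other groups at the same place, such as an amine, a carboxylic acid or a longer chain, would also give numbers within the scatter of compound 2, since phenyl to 4-(tert-butyl)phenyl is the only change at this position so far. They also leave open whether tert-butyl would give a similar step on the core of compound 1, where the nitrogen carries no (1-bromoethenyl)carbonyl.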